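The compounds below may be only part of what the source reports. "The series", "measured", "known", "first", "only" and "open" are said of these compounds alone.

Measured compounds:
compound 1 `CS(=O)(=O)c1ccc(C(=O)Nc2cccc(Cl)c2)cc1` gives 7600 nM in an assay on Expi293F cells for binding affinity to adenosine receptor A1 (Homo sapiens), read by surface plasmon resonance; on this read-out higher numbers stand for weaker binding and lower numbers for tighter binding
compound 2 `Nc1nsc(-c2ccccc2)n1` gives 122000 nM in this assay

Compound 2 has the higher of the two numbers; compound 1 sits well below it, beyond the scatter. Compound 3 `Nc1nsc(-c2ccc(Cl)cc2)n1` keeps the core of compound 2 and differs by chloro in place of hydrogen on an aromatic carbon. Going by the values given here, no measured pair shows this change, so its size is unknown. The step from compound 2 to compound 3 is expected to be a modest lowering of the dissociation constant, a 2.4-fold lower number from compound 2 to compound 3 (0.39 log units; beyond the scatter), though a step within the scatter cannot be excluded. Compound 3 is therefore estimated at 50000 nM, with a range of 15000 nM to 150000 nM.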

Compound 3, dissociation constant: 20700 nM
Estimate against measurement, compound 3: 2.4-fold (0.38 log units) above; the measured number falls inside the stated range.
By their numbers in this assay, from the lowest: compound 1; then compound 3; then compound 2.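

Chloro in place of hydrogen on an aromatic carbon, para to a group of 6 heavy atoms, tightens binding in this assay, with a 5.9-fold lower number from compound 2 to compound 3 (0.77 log units; beyond the scatter). Going by these compounds alone, this is the first step that can be read at a single place, and it shows that this position takes one chlorine with a lower number, not a higher one. Nothing available explains the size of this step.

Going by these compounds, whether the lower number is particular to chloro remains open. A methoxy group, an amine or a carboxylic acid at the same place could shift the number either way.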